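The source may hold more compounds than are shown below. What is called first, only, known or untested is meant among the compounds shown, and "the series" means these compounds.

In a functional assay on HT-29 cells (Homo sapiens) for antiproliferative activity, read by MTT assay, with a stated time of 48 h (on this read-out lower numbers stand for stronger inhibition of growth and higher numbers for weaker inhibition of growth), compound 1 (`COC(=O)N1N=C(c2ccccc2)CC1c1cc(OC)c(OC)c(OC)c1`) gives 6260 nM and stands within the scatter of both measured neighbours: compound 2 (`CCOC(=O)N1N=C(c2ccccc2)CC1c1cc(OC)c(OC)c(OC)c1`) gives 8920 nM and compound 3 (`COC(=O)N1N=C(c2ccccc2)CC1c1ccc(OC)c(OC)c1`) gives 10700 nM in the same series. Compound 4 (`COC(=O)N1N=C(c2ccc(O)cc2)CC1c1cc(OC)c(OC)c(OC)c1`) carries hydroxy in place of hydrogen on an aromatic carbon as the phenyl becomes 4-hydroxyphenyl. Neither a 1.4-fold higher number from compound 1 to compound 2 (0.15 log units; within the scatter) nor a 1.7-fold higher number from compound 1 to compound 3 (0.23 log units; within the scatter) touches that phenyl, although the second also changes an aromatic carbon. The data therefore set no direction for this change. The step expected is a 1.0-fold lower number from compound 1 to compound 4 (0.02 log units; within the scatter) and thus none beyond the scatter. In this assay compound 4 is estimated at 6000 nM with 2000 nM to 18000 nM as the expected range.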

Compound 4, concentration for 50% growth inhibition: 6770 nM
Compound 4: the middle estimate sits 1.1-fold (0.05 log units) below what was measured, within the range that was stated.
By their numbers in this assay, from the lowest: compounds 1, 4, 2 and 3 (each within the scatter of the next).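

Of the steps shown, only this one touches the phenyl: in this assay, hydroxy in place of hydrogen on an aromatic carbon, para to a large group, gives a small step (a 1.1-fold higher number from compound 1 to compound 4 (0.03 log units; within the scatter)). This place on the ring therefore takes a hydroxy, with its hydrogen-bond donor and acceptor, with no difference beyond the scatter. No supporting evidence is available to account for this result.

As far as these compounds go, whether an amine or a carboxylic acid at the same place would also stay within the scatter remains open. So does whether hydroxy would behave alike on the other carbons of that ring.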